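Imine substituent exchange on the core of compound 1

The source may hold more compounds than are shown below. What is called first, only, known or untested is meant among the compounds shown, and "the series" means these compounds.

Among the measured compounds shown here, compound 1 `C/C(=N\Nc1ccccc1)c1c(O)c2ccccc2oc1=O` is the only member of this small set with a number in an assay on isolated protein for inhibition of myosin-2 (Bos taurus), read by spectrophotometry, with a stated time of 24 min; on this read-out higher numbers stand for weaker inhibition and lower numbers for stronger inhibition: in this assay compound 1 gives 27000 nM, which is weak inhibition. Compound 2 `C/C(=N\CC1CCCCC1)c1c(O)c2ccccc2[nH]c1=O` differs from compound 1 in more than one place. In this assay compound 2 returns >= 100000 nM, which is a limit of the assay and not a number (the limit of >= 100000 nM in this assay, at which 1 of the 2 values shown sits). For the measured compounds named here, the two values therefore show one weak inhibitor and one compound that did not reach measurable inhibition; no step between measured compounds that differ in a single place is available.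

Compound 3 `C/C(=N\Cc1ccccn1)c1c(O)c2ccccc2oc1=O` is the compound still to be measured. It carries (pyridin-2-yl)methyl in place of anilino on a double-bonded nitrogen. Going by the values given here, with no measured single-place step to lean on, the expectation rests on compound 1 alone and on the general weakness of the set. The step from compound 1 to compound 3 is expected to be a 2.2-fold higher number from compound 1 to compound 3 (0.35 log units; beyond the scatter), towards weaker inhibition, probably beyond the usual scatter. Compound 3 is expected to come out near 60000 nM in this assay, with a likely range from 20000 nM to 200000 nM, and a fair chance that only a limit is returned.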

Compound 3, half-maximal inhibitory concentration: 22000 nM
Beside the measured number, compound 3's estimate is 2.7-fold (0.44 log units) above it, within the range that was stated.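

Working notes on the imine substituent: in this assay the exchange of anilino for (pyridin-2-yl)methyl on a double-bonded nitrogen gives a 1.2-fold lower number from compound 1 to compound 3 (0.09 log units; within the scatter) and is the first single-place step in the series. At this position, the two groups cannot be told apart on this read-out, so both compounds remain weak inhibitors. The exchange keeps the count of heavy atoms, removes the hydrogen-bond donor counted on anilino and places a hetero atom in the aromatic ring, yet this pair shows no change beyond the scatter, and the donor is therefore not required to retain the weak inhibition seen with compound 1.

As far as these compounds go, whether a primary amine, a carboxylic acid or a longer alkyl chain on the same nitrogen would move the number beyond the scatter remains open, as does the separate contribution of each difference between compound 2 and the other compounds. Compound 2 carries a limit of the assay and not a number, and its steps to the other compounds cannot be read: the limit of >= 100000 nM in this assay, at which 1 of the 3 values shown sits.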